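A few compounds are considered here, and "the series" means these few. Any claim that something is new, unique, unknown or untested is made for them only; others in the source may bear on it.

Measured compounds in the series:

Compound 1, `Cc1cc(Cl)c(-c2ncc[nH]2)cc1NC(=O)c1ccc(OCc2ccccn2)cc1`: in a physicochemical assay for lipophilicity (a lower number here means a more polar compound, a higher number a more lipophilic compound), compound 1 gives > 3, which is a limit of the assay and not a number.
Compound 2, `Cc1cc(C)c(-c2cn(C)cn2)cc1NC(=O)c1ccc(OCc2ccccn2)cc1`: in this assay compound 2 gives 3.
Compound 3, `Cc1csc(-c2cc(NC(=O)c3ccc(OCc4ccccn4)cc3)c(C)cc2C)n1`: in this assay compound 3 gives > 3, again a limit of the assay rather than a number.

Compound 3 therefore stands at the upper limit of this assay, at the limit of > 3 in this assay, at which 2 of the 3 values shown sit. Where it lies relative to compound 1 cannot be read, since both values are limits. Compound 4, `Cc1cc(C)c(-c2ccccn2)cc1NC(=O)c1ccc(OCc2ccccn2)cc1`, differs from compound 3 in one place: pyridin-2-yl in place of 4-methyl-1,3-thiazol-2-yl on an aromatic carbon.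

Among the measured compounds shown here, the single measured step that touches this position is a number no lower from compound 2 to compound 3 (the limit leaves the size open); its size stays open because compound 3 sits at the limit. For the measured compounds named here, compounds 1 and 2 differ in two places, so their values give no single-change step. Going by the values given here, no measured step covers pyridin-2-yl itself.

Among the compounds with values here, with only a limit on compound 3 and no step of known size, the change a number no higher from compound 3 to compound 4 (the limit leaves the size open) is expected to be small or unreadable. Compound 4 is expected to give about 3 in this assay, within 2.6 to 3.4, with a fair chance that only a limit is reported again.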

Compound 4, distribution coefficient: > 3
Compound 4 gave a limit, no number (the forecaster's own chance of this, stated with the estimate: 50%); the middle value lies on the limit itself.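

In this assay compound 4 gives > 3 and this is a limit of the assay, not a number. Pyridin-2-yl in place of 1-methyl-1H-imidazol-4-yl on this aromatic carbon gives a number no lower from compound 2 to compound 4 (the limit leaves the size open) and so reads in the same direction as 4-methyl-1,3-thiazol-2-yl, showing that this outcome is not confined to the five-membered aromatic ring with a sulfur atom. The step between the pyridin-2-yl and 4-methyl-1,3-thiazol-2-yl compounds cannot be read, and the series now gathers at the top of the assay's range: the limit of > 3 in this assay, at which 3 of the 4 values shown sit.

As far as these compounds go, the size of each step away from 1-methyl-1H-imidazol-4-yl stays open, as does any ordering of pyridin-2-yl and 4-methyl-1,3-thiazol-2-yl. Also open is how this position would read with a carboxylic acid or an amine on this aromatic carbon, in place of the aromatic rings shown so far.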